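Side-chain change carried from an acid to a benzyl ester

This account rests on a few compounds, and the source may have more. Where it says the series, first, only, none or still open, it means among the compounds named here.

Of the compounds shown here, three with a shared core have been tested in a functional assay on the whole organism (Tail, strain ICR) with Mus musculus as the target, in the tail flick test, with a stated time of 90 min, at a dose of 25 umol/kg by the oral route; on this read-out lower numbers stand for a weaker effect and higher numbers for a stronger effect at the one dose given. Compound 1 `NC(=O)C[C@H](NC(=O)CN(c1nc(Cl)nc2[nH]cnc12)C1CC1)C(=O)O` gives 20.1% in this assay. Compound 2 `CC(C)[C@H](NC(=O)CN(c1nc(Cl)nc2[nH]cnc12)C1CC1)C(=O)O` carries isopropyl in place of carbamoylmethyl on a saturated chain carbon bound to an amide-type nitrogen and a carbonyl carbon and in this assay compound 2 gives 30.3%, a step of a number 10.2 percentage points higher from compound 1 to compound 2 (beyond the scatter). Compound 3 `NC(=O)CC[C@H](NC(=O)CN(c1nc(Cl)nc2[nH]cnc12)C1CC1)C(=O)OCc1ccccc1` differs from compound 1 in more than one place, and the difference between the two cores is not broken down here. In this assay compound 3 gives 42.8%, the highest of the three numbers, beyond the scatter from both compound 2 and compound 1.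

Compound 4 `CC(C)C[C@H](NC(=O)CN(c1nc(Cl)nc2[nH]cnc12)C1CC1)C(=O)OCc1ccccc1` has not yet been measured. Relative to compound 3 it shows (isopropyl in place of carbamoylmethyl on a saturated chain carbon, two bonds along the chain from an amide-type nitrogen and a carbonyl carbon). For the measured compounds named here, this is the same kind of change as the one from compound 1 to compound 2, but not the same: there the group sat on a saturated chain carbon bound to an amide-type nitrogen and a carbonyl carbon, whereas here it sits on a saturated chain carbon two bonds along the chain from an amide-type nitrogen and a carbonyl carbon. The earlier step gave a number 10.2 percentage points higher from compound 1 to compound 2 (beyond the scatter). Going by the values given here, with only that one pair behind it and the place shifted by one bond, the expected step is a number 9.2 percentage points higher from compound 3 to compound 4 (within the scatter), a modest rise of roughly the earlier size. Compound 4 is therefore estimated at 52% in this assay, with a likely range from 36% to 68%.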

Compound 4, a percentage reported as activity, at one dose (the size of the read-out at that dose, not a potency): 15.2%
The estimate for compound 4 lay 36.8 percentage points above the measured number; measured number outside the range, below it.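

On the benzyl ester, putting isopropyl in place of carbamoylmethyl gives a number 27.6 percentage points lower from compound 3 to compound 4 (beyond the scatter) in this assay, so the change does not keep the direction it had on the acid. Set side by side, the two steps disagree, and the change therefore cannot be carried from one core to the other in this series with its sign or its size intact: the same change on two cores in this assay, a number 10.2 percentage points higher (beyond the scatter) from compound 1 to compound 2 and a number 27.6 percentage points lower (beyond the scatter) from compound 3 to compound 4, 37.8 percentage points apart, beyond the scatter of two such steps

This does not show what separates the two results. For the compounds shown here, each core offers only one pair, and the two pairs differ both in the acid or benzyl ester and in where the group sits, so these two differences cannot be told apart, and each step is read at a single dose and a single time.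

The compounds shown leave open how the carboxylic acid bearing 2-carbamoylethyl or isobutyl would compare with the benzyl esters of compound 3 and compound 4, and how benzyl esters of compound 1 and compound 2 would read, since such pairs would separate the ester from the place. Also open, from the compounds shown here alone, is whether a methyl ester or a primary amide in place of the benzyl ester would follow the acid pair, the benzyl ester pair or neither.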